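A few compounds are considered here, and "the series" means these few. Any claim that something is new, unique, unknown or untested is made for them only; others in the source may bear on it.

Compound 1 `CCn1c(C(=O)NC2(CO)CC2)ccc1C(CC)(CC)c1ccc(OCS(=O)(=O)c2ccccc2)c(C)c1` is the anchor of this short series. In a functional assay on PC-3 cells (Homo sapiens) for antiproliferative activity, read by MTT assay, with a stated time of 24 h (on this read-out higher numbers stand for weaker inhibition and lower numbers for stronger inhibition), compound 1 gives 3560 nM, the lowest number among the three measured compounds. Compound 2 `CCn1c(C(=O)N[C@H](CO)CCO)ccc1C(CC)(CC)c1ccc(OCS(=O)(=O)c2ccccc2)c(C)c1` gives 12100 nM, and compound 3 `CCn1c(C(=O)N[C@@H](CO)CCCO)ccc1C(CC)(CC)c1ccc(OCS(=O)(=O)c2ccccc2)c(C)c1` gives 13400 nM; both carry an open-chain amide substituent in place of the ring-bearing one, and both sit beyond the scatter from compound 1, as seen in a 3.4-fold higher number from compound 1 to compound 2 (0.53 log units; beyond the scatter) and a 3.8-fold higher number from compound 1 to compound 3 (0.58 log units; beyond the scatter). Between compound 2 and compound 3 the step of a 1.1-fold higher number from compound 2 to compound 3 (0.04 log units; within the scatter) lies within the scatter.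

Compound 4 `CCn1c(C(=O)N[C@@H](CCC(=O)O)C(=O)O)ccc1C(CC)(CC)c1ccc(OCS(=O)(=O)c2ccccc2)c(C)c1` is not yet measured. It differs from compound 1 as follows: 1,3-dicarboxypropyl in place of 1-(hydroxymethyl)cyclopropyl on an amide-type nitrogen. For the measured compounds named here, the only steps that bear on it are the two in which the ring-bearing group left the amide nitrogen for an open chain, each costing a modest loss. The entering group here is larger again and carries two carboxylic acids, so a further loss is expected rather than a gain. For compound 4 the expected outcome is a 4.2-fold higher number from compound 1 to compound 4 (0.62 log units; beyond the scatter), placing compound 4 at an estimated 15000 nM in this assay, with a range from 5000 nM to 45000 nM.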

Compound 4, half-maximal inhibitory concentration: > 50000 nM
Compound 4: only a limit was reported; the forecaster's own chance of this, stated with the estimate: 30%; middle value at least 3.3-fold (0.52 log units) away from the limit.
By their numbers in this assay, from the lowest: compound 1; then compounds 2 and 3 (each within the scatter of the next). At a limit, above all of these: compound 4.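

Compound 4 is reported only as a limit of the assay: the limit of > 50000 nM in this assay, at which 1 of the 4 values shown sits. On the amide-type nitrogen, 1,3-dicarboxypropyl costs far more than either earlier open chain, with an at least 14-fold higher number from compound 1 to compound 4 (1.14 log units; beyond the scatter) standing against the modest steps seen before. For the compounds shown here, for the first time, open-chain groups at this place also separate from one another in this assay, through an at least 4.1-fold higher number from compound 2 to compound 4 (0.61 log units; beyond the scatter) and an at least 3.7-fold higher number from compound 3 to compound 4 (0.57 log units; beyond the scatter), so the loss on leaving the 1-(hydroxymethyl)cyclopropyl group depends on which chain enters.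

As far as these compounds go, whether a single carboxylic acid, a methyl ester of these acids or an amine on the same chain would bring a comparable loss remains open. From the compounds shown here alone, with only a limit for compound 4, the full size of its loss also remains unknown, as does how that loss divides between the longer chain and the two carboxylic acids.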